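Quinoxaline diamines: dimethoxy for dichloro on the benzylamine

The source may hold more compounds than are shown below. What is called first, only, known or untested is meant among the compounds shown, and "the series" means these compounds.

Compound 1 `Nc1cc(N)c2nc(-c3ccccc3)c(Oc3ccc(Cl)c(Cl)c3)nc2c1`: 20400 nM
Compound 2 `CCOC(=O)[C@H](CCC(=O)O)NC(=O)c1ccc(CNc2nc3cc(N)cc(N)c3nc2-c2ccccc2)cc1`: 19500 nM
Compound 3 `Nc1cc(N)c2nc(-c3ccccc3)c(NCc3ccc(Cl)c(Cl)c3)nc2c1`: 17000 nM

In a functional assay on COLO 205 cells (Homo sapiens) for inhibition, read by sulforhodamine B assay, with a stated time of 48 h (on this read-out higher numbers stand for weaker inhibition of growth and lower numbers for stronger inhibition of growth), compound 3 gives 17000 nM. Among the three measured compounds this is the lowest number, yet the gap to compound 2 and to compound 1 lies within the scatter of repeated measurements, so no order among them can be read from these values. Compound 4 `COc1ccc(CNc2nc3cc(N)cc(N)c3nc2-c2ccccc2)cc1OC` has not been measured in this assay. It differs from compound 3 in one place: 3,4-dimethoxyphenyl in place of 3,4-dichlorophenyl on a saturated chain carbon bound to a nitrogen on an aromatic ring. For the measured compounds named here, no measured pair in this set shows what such an exchange does to the read-out; the three measured compounds, with their different groups at the same general region, all land at nearly the same number. On that basis the author expects the step from compound 3 to compound 4 to be a 1.2-fold higher number from compound 3 to compound 4 (0.07 log units; within the scatter), with no direction beyond the scatter. For compound 4 the estimate in this assay is 20000 nM, with a range from 8000 nM to 50000 nM.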

Compound 4, concentration for 50% growth inhibition: 7940 nM
Estimate against measurement, compound 4: 2.5-fold (0.40 log units) above; the measured number lies below the stated range.
By their numbers in this assay, from the lowest: compound 4; then compounds 3, 2 and 1 (each within the scatter of the next).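

In this assay, for the compounds shown here, the exchange of 3,4-dichlorophenyl for 3,4-dimethoxyphenyl on a saturated chain carbon bound to a nitrogen on an aromatic ring gives a 2.1-fold lower number from compound 3 to compound 4 (0.33 log units; beyond the scatter) and is the first single change here to move the number beyond the scatter, though only modestly. The earlier compounds shown here contained no pair differing in one place, so their similar numbers could not show that the read-out responds to the group at this position. Nothing available explains this response.

Going by these compounds, whether both methoxy groups are needed remains open, as does whether an amine or a carboxylic acid on this phenyl ring would lower the number further. On these data alone, it is also open whether 3,4-dimethoxyphenyl would have the same effect in place of the 3,4-dichlorophenyl of compound 1.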